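This account rests on a few compounds, and the source may have more. Where it says the series, first, only, none or still open, it means among the compounds named here.

Working notes on the series. Compound 1 `FC(F)(F)c1ccc(CN2CCN(Cc3cc(-c4ccc(OCc5ccc(Cl)cc5)cc4)on3)CC2)cc1` and compound 2 `N#Cc1ccc(COc2ccc(-c3cc(CN4CCN(Cc5ccc(C(F)(F)F)cc5)CC4)no3)cc2)cc1` share one core and differ in a single group on the outer aromatic ring. In a functional assay on Huh-7 cells (Homo sapiens) for antiproliferative activity, read by sulforhodamine B assay, with a stated time of 72 h (a higher number here means a weaker inhibitor, a lower number a stronger inhibitor), compound 1 gives 4000 nM and compound 2 gives 1000 nM. The step of a 4.0-fold lower number from compound 1 to compound 2 (0.60 log units; beyond the scatter) is the only measured move in the set so far. On the numbers shown, compound 2 stands lowest of the two, its nearest neighbour being compound 1 at a higher number, the gap being the step already given.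

Compound 3 `COc1ccc(COc2ccc(-c3cc(CN4CCN(Cc5ccc(C(F)(F)F)cc5)CC4)no3)cc2)cc1` is not yet measured. It differs from compound 2 by methoxy in place of cyano on an aromatic carbon. Among the compounds with values here, the one measured step that bears on this change is the exchange of chloro for cyano at the same place, which moved the number by a 4.0-fold lower number from compound 1 to compound 2 (0.60 log units; beyond the scatter); it shows that this group is sensitive, but it gives no direction for methoxy, which is neither chloro nor cyano. A modest step is therefore expected, of uncertain sign, and the estimate a 2.0-fold higher number from compound 2 to compound 3 (0.30 log units; within the scatter) is set near no change with a wide range. For compound 3 the expected value in this assay is 2000 nM, between 600 nM and 7000 nM.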

Compound 3, half-maximal inhibitory concentration: 3200 nM
The estimate for compound 3 lay 1.6-fold (0.20 log units) below the measured number, within the range that was stated.
By their numbers in this assay, from the lowest: compound 2; then compounds 3 and 1 (each within the scatter of the next).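

The exchange of cyano for methoxy on this aromatic carbon, para to a large group, gives a 3.2-fold higher number from compound 2 to compound 3 (0.51 log units; beyond the scatter) in this assay and so supplies the direction that the chloro-to-cyano step could not give for methoxy. Alongside this, a 1.3-fold lower number from compound 1 to compound 3 (0.10 log units; within the scatter) places methoxy and chloro within the scatter of each other, so the two cannot be separated at this position, while cyano in compound 2 stands apart from both with the lowest number of the three. The series therefore shows sensitivity here as a difference between cyano and the other two groups rather than a graded trend, and nothing available accounts for that difference.

Three groups at one position cannot show whether cyano is singular or merely one of several groups giving lower numbers here, and a carboxylic acid, a primary amine or a carboxamide on the same carbon would test that. As far as these compounds go, it also remains open whether the separation of cyano from methoxy and chloro persists when the trifluoromethyl group elsewhere in the shared core is replaced by another group, such as a methoxy or a fluoro.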